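Dichloro to difluoro on the ketone-bearing ring

The source may hold more compounds than are shown below. What is called first, only, known or untested is meant among the compounds shown, and "the series" means these compounds.

Measured so far:
compound 1 `COc1ccc(-c2cc(/C=C/C(=O)c3ccc(N)cc3)[nH]n2)cc1`, -67%
compound 2 `COc1cc(-c2cc(/C=C/C(=O)c3ccc(N)cc3)[nH]n2)cc(OC)c1OC`, -49%
compound 3 `COc1cc(-c2cc(/C=C/C(=O)c3ccc(Cl)c(Cl)c3)[nH]n2)cc(OC)c1OC`, 9%

All three were tested in a functional assay on IGROV-1 cells (Homo sapiens) for cytotoxicity, read by sulforhodamine B assay, with a stated time of 48 h, tested at 100 uM; on this read-out lower numbers stand for a stronger effect and higher numbers for a weaker effect at the one concentration tested. Compound 1 gives -67% and compound 2 gives -49%, while compound 3 gives 9%, the highest of the three numbers, that is the weakest effect. For the measured compounds named here, the one measured step that changes the same part of the structure is a number 58 percentage points higher from compound 2 to compound 3 (beyond the scatter), so swapping the ring on the carbonyl carbon has already moved the read-out a great deal once.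

Compound 4 `COc1cc(-c2cc(/C=C/C(=O)c3ccc(F)c(F)c3)[nH]n2)cc(OC)c1OC` is made from compound 3 by 3,4-difluorophenyl in place of 3,4-dichlorophenyl on a carbonyl carbon. Going by the values given here, no measured pair shows a chlorine-for-fluorine exchange, so the only guide is that the ring keeps its size and pattern and only the halogen differs. A step of a number 4 percentage points lower from compound 3 to compound 4 (within the scatter) in this assay is therefore expected, that is, none beyond the scatter. For compound 4 the estimate is 5%, between -25% and 30%.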

Compound 4, a percentage reported as activity, at one concentration (the size of the read-out at that concentration, not a potency): -1%
For compound 4 the middle estimate is 6 percentage points above the measured one; measured number inside the range.
By their numbers in this assay, from the lowest: compound 1; then compound 2; then compounds 4 and 3 (each within the scatter of the next).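

In this assay the exchange of 3,4-dichlorophenyl for 3,4-difluorophenyl on the carbonyl carbon is a number 10 percentage points lower from compound 3 to compound 4 (within the scatter), so the read-out does not separate these two halogens at this position. The large shift remains tied to leaving 4-aminophenyl: putting 3,4-difluorophenyl in its place gives a number 48 percentage points higher from compound 2 to compound 4 (beyond the scatter), and this second dihalogenated ring parts from 4-aminophenyl much as the dichloro ring did in a number 58 percentage points higher from compound 2 to compound 3 (beyond the scatter). Nothing measured here explains why the 4-aminophenyl compound stands apart from the two dihalogenated ones.

Going by these compounds, it remains open whether the amine itself matters, which a plain phenyl ring, or a hydroxyl or dimethylamino group in place of the amine, could test. Also open, on these data alone, is whether 3,4-difluorophenyl would behave the same way on the core of compound 1.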